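From oxolan-2-yl to oxetan-2-yl in a permeability series

A few compounds are considered here, and "the series" means these few. Any claim that something is new, unique, unknown or untested is made for them only; others in the source may bear on it.

In an ADME assay on MDCKII-LE cells (Canis lupus familiaris) for permeability, read by transwell migration, in the apical to basolateral direction (on this read-out lower numbers stand for lower permeability and higher numbers for higher permeability), compound 1 `CC1(C)C[C@@H](CN([C@H](CCC(F)(F)F)C(N)=O)S(=O)(=O)c2ccc(Cl)cc2)O1` gives 14.9 10^-6 cm/s, and compound 2 `NC(=O)[C@@H](CCC(F)(F)F)N(C[C@@H]1CCCO1)S(=O)(=O)c1ccc(Cl)cc1` gives 22.4 10^-6 cm/s. Among the measured compounds shown here, these are the only two numbers available, and they lie within the usual scatter of each other, so compound 2 stands level with compound 1.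

Compound 3 `NC(=O)[C@@H](CCC(F)(F)F)N(C[C@H]1CCO1)S(=O)(=O)c1ccc(Cl)cc1` differs from compound 2 at a single place: oxetan-2-yl in place of oxolan-2-yl on a saturated chain carbon bound to a sulfonamide nitrogen. In words, it carries oxetan-2-yl in place of oxolan-2-yl on a saturated chain carbon bound to a sulfonamide nitrogen.

For the measured compounds named here, only one measured step bears on this change, since it alters the group at the same place. That step, in which oxolan-2-yl replaces 4,4-dimethyloxetan-2-yl, is a 1.5-fold higher number from compound 1 to compound 2 (0.18 log units; within the scatter). It stayed within the scatter, so no step beyond the scatter is expected in this assay, and the data give only a weak hint of direction. The estimated move, a 1.2-fold lower number from compound 2 to compound 3 (0.09 log units; within the scatter), is expected to stay within the scatter. For compound 3 the estimate is 18 10^-6 cm/s, with an expected range of 10 10^-6 cm/s to 32 10^-6 cm/s.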

Compound 3, apparent permeability in the MDCKII-LE assay: 28.7 10^-6 cm/s
Beside the measured number, compound 3's estimate is 1.6-fold (0.20 log units) below it; measured number inside the range.
By their numbers in the MDCKII-LE assay, from the lowest: compounds 1, 2 and 3 (each within the scatter of the next).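

In the MDCKII-LE assay, the change to oxetan-2-yl on a saturated chain carbon bound to a sulfonamide nitrogen gives a 1.3-fold higher number from compound 2 to compound 3 (0.11 log units; within the scatter), and the same group in place of 4,4-dimethyloxetan-2-yl gives a 1.9-fold higher number from compound 1 to compound 3 (0.28 log units; within the scatter), so all three groups at this place stand level. The earlier compounds shown here offered no view of a physicochemical assay for lipophilicity, read by HPLC, measured as octanol-water partition, at pH 7.4 (on this read-out lower numbers stand for lower lipophilicity and higher numbers for higher lipophilicity), and here compound 2 gives 3.5 and compound 3 gives 2.6, so the change from oxolan-2-yl to oxetan-2-yl separates the pair clearly: the measured distribution coefficient of compound 2, 3.5, and of compound 3, 2.6, a number 0.90 log units lower (beyond the scatter) In this one pair, then, the apparent permeability stays level while the distribution coefficient does not, a split that compound 1 and compound 2 alone could not reveal.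

The compounds shown leave open whether a ring carrying an amine, such as azetidin-2-yl, or an open chain such as 2-methoxyethyl at this place would also stay level in the MDCKII-LE assay. With a single pair read in both assays, they also leave open whether the same split would appear on any core other than the shared one, and the three permeability numbers set no trend with ring size.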